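The compounds below may be only part of what the source reports. "The series", "measured", "known", "first", "only" and "open" are said of these compounds alone.

Of the compounds shown here, three built on one shared core have been tested in a functional assay for inhibition, with Homo sapiens as the target; a higher number here means a weaker inhibitor, a lower number a stronger inhibitor. Compound 1, `COc1ccc(C(=O)c2nc(-c3ccc4c(c3)CCC(=O)N4)cs2)cc1OC`, gives 1000 nM, and compound 2, `COc1ccc(/C=C/c2nc(-c3ccc4c(c3)CCC(=O)N4)cs2)cc1OC`, gives 2800 nM. Compound 3, `COc1cc(-c2nc(-c3ccc4c(c3)CCC(=O)N4)cs2)ccc1SC`, gives 400 nM. That is the lowest of the three numbers, and its gaps to both of the others lie beyond the usual scatter of repeated measurements, so compound 3 is the strongest inhibitor of the set so far. For the measured compounds named here, these three compounds differ in more than one place, so no measured pair isolates the effect of a single change.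

The next compound to consider is compound 4, `CCOc1ccc(-c2nc(-c3ccc4c(c3)CCC(=O)N4)cs2)cc1OC`. It has ethoxy in place of methylsulfanyl on an aromatic carbon, ortho to a methoxy group and para to a large group: ethoxy in place of methylsulfanyl on an aromatic carbon. Going by the values given here, no measured pair shows what this swap does, so any forecast has little direct support. The best starting point is compound 3 at 400 nM, which matches compound 4 everywhere except at this one group. A small move toward a weaker inhibitor, not beyond the scatter, is expected, and the estimated step is a 1.5-fold higher number from compound 3 to compound 4 (0.18 log units; within the scatter). The expected value for compound 4 is 600 nM, with an estimated range of 200 nM to 1800 nM.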

Compound 4, half-maximal inhibitory concentration: 600 nM
Estimate against measurement, compound 4: no gap at the digits printed, within the range that was stated.
By their numbers in this assay, from the lowest: compounds 3, 4 and 1 (each within the scatter of the next, the first and the last beyond it); then compound 2.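

For the compounds shown here, this is the first pair in the set that differs in only one place, so it gives the first direct reading of a single change. On the aromatic carbon ortho to a methoxy group and para to a large group, ethoxy in place of methylsulfanyl gives, in this assay, a 1.5-fold higher number from compound 3 to compound 4 (0.18 log units; within the scatter). This position therefore accepts a swap from methylsulfanyl, with 2 heavy atoms including sulfur, to ethoxy, with 3 heavy atoms including oxygen, without a change that stands out from the scatter, and no measurement shown here offers an explanation for this result.

On these data alone, the two groups compared are alike in having no ring, no hydrogen-bond donor and no net charge, so it remains open how an amine, a carboxylic acid, a longer chain such as butoxy or a plain hydrogen would read at this position. As far as these compounds go, it also remains open whether the same swap would give a similar step in compounds with the carbonyl link of compound 1 or the carbon-carbon double bond link of compound 2.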